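A few compounds are considered here, and "the series" means these few. Any claim that something is new, unique, unknown or untested is made for them only; others in the source may bear on it.

Measured so far:
- compound 1, `CCCC(CCC)C(=O)NC(N)=O`: 54 mg/kg
- compound 2, `CC(C)C(C(=O)NC(N)=O)C(C)C`: 33 mg/kg
- compound 3, `CCC[C@H](C(N)=O)C(C)C`: 63 mg/kg

These three compounds were tested in a functional assay on the whole organism (strain Sprague-Dawley) with Rattus norvegicus as the target, in the maximal electroshock model; a lower number here means that less compound is needed, a higher number that more compound is needed for the effect. Compound 1 gives 54 mg/kg, compound 2 gives 33 mg/kg, and compound 3 gives 63 mg/kg. The gap between compound 3 and compound 1 is small, and even the gap between compound 3 and compound 2 stays within the scatter of repeated measurements, so none of the three can be called more or less active than another on the present numbers.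

Compound 3 is a primary amide with a propyl and an isopropyl branch on its core. Compounds 1 and 2 carry, on the amide-type nitrogen, a carbamoyl group instead of a hydrogen, which makes them ureido rather than amino at that position. The unmeasured compound 4, `CCC[C@H](C(=O)NC(N)=O)C(C)C`, applies the same change to compound 3: carbamoyl in place of hydrogen on an amide-type nitrogen.

Compounds 1 and 2 share this ureido arrangement and both fall at or somewhat under the value of compound 3, which suggests that in this assay the step from compound 3 to compound 4 is expected to be a small lowering, likely still within the scatter, of about a 1.5-fold lower number from compound 3 to compound 4 (0.18 log units; within the scatter). Compound 4 is therefore estimated to give 42 mg/kg, with a range from 22 mg/kg to 80 mg/kg.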

Compound 4, dose for half-maximal effect: 18 mg/kg
For compound 4 the middle estimate is 2.3-fold (0.37 log units) above the measured one, outside the stated range (below it).
By their numbers in this assay, from the lowest: compounds 4, 2, 1 and 3 (each within the scatter of the next, the first and the last beyond it).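

In this assay putting a carbamoyl group in place of hydrogen on the amide-type nitrogen gives a 3.5-fold lower number from compound 3 to compound 4 (0.54 log units; beyond the scatter) and this modest step lies beyond the usual scatter of repeated measurements. The earlier compounds shown here could not show this, since no two of them differ in only one place, so the change from amino to ureido had no direct reading until this pair; with the propyl and isopropyl branches unchanged, the ureido form needs less compound for the effect than the primary amide. No measurement available here accounts for the size of this step or for its direction.

Whether the same change gives a similar step with other branches stays open, as compounds 1 and 2 have no primary amide partner among the compounds shown, and a single pair sets no general rule. Also open, as far as these compounds go, is what other groups would do at this position, such as a methyl or an acetyl group on the nitrogen in place of the carbamoyl, or a carboxylic acid in place of the whole amide.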